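The compounds below may be only part of what the source reports. "The series", "measured", "known", "first", "only" and "open" are said of these compounds alone.

Measured so far in a functional assay on RAW264.7 cells (Mus musculus) for inhibition, read by polymerase chain reaction, with stated times of 12 h and 6 h; a lower number here means a stronger inhibitor, a higher number a weaker inhibitor:

compound 1, `Cc1ccc(C)c(OCCCC(C)(C)C(=O)NC2CCN(Cc3ccc(C(F)(F)F)cc3)CC2)c1`, gives 5170 nM
compound 2, `COc1ccc(CN2CCC(NC(=O)C(C)(C)Oc3ccc(C(=O)c4ccc(Cl)cc4)cc3)CC2)cc1`, gives 4570 nM
compound 3, `CC(C)(Oc1ccc(C(=O)c2ccc(Cl)cc2)cc1)C(=O)NC1CCN(Cc2ccc(C(F)(F)F)cc2)CC1`, gives 4400 nM

Compound 1 has the highest number of the three, yet its gap to compound 2 and its gap to compound 3 both lie within the scatter of repeated measurements, so these three compounds cannot be told apart on the numbers in hand. Compound 4, `Cc1ccc(C)c(OCCCC(C)(C)C(=O)NC2CCN(Cc3ccc(F)cc3)CC2)c1`, is compound 1 with a single change: fluoro in place of trifluoromethyl on an aromatic carbon. Among the compounds with values here, the one measured step, a 1.0-fold lower number from compound 2 to compound 3 (0.02 log units; within the scatter), also swaps one group for another on an aromatic carbon of the benzyl ring and left the number unchanged within the scatter. Within the data shown here, it does not involve fluoro, and no measured compound carries fluoro, so the guidance is indirect. On that basis the expectation for compound 4 is a step of a 1.0-fold lower number from compound 1 to compound 4 (0.01 log units; within the scatter), that is, nothing beyond the scatter. Compound 4 is therefore estimated at 5000 nM in this assay, with a range from 2000 nM to 12500 nM.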

Compound 4, half-maximal inhibitory concentration: 4560 nM
Compound 4: the middle estimate sits 1.1-fold (0.04 log units) above what was measured, and the stated range covers the measured number.
By their numbers in this assay, from the lowest: compounds 3, 4, 2 and 1 (each within the scatter of the next).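

In this assay, putting fluoro in place of trifluoromethyl on the aromatic carbon para to a large group gives a 1.1-fold lower number from compound 1 to compound 4 (0.05 log units; within the scatter), so a single fluorine atom stands where a group of four heavy atoms stood without moving the number beyond the scatter. Within the data shown here, the earlier compounds compared only methoxy and trifluoromethyl at this place, on a different core, so this is the first reading for fluoro and the first change here on the core of compound 1. No measurement shown gives a reason for this result.

On these data alone, neither step at this place goes beyond the scatter, so it stays open whether an amine or a carboxylic acid there would shift the number. As far as these compounds go, it is equally open what a plain hydrogen there, with no group at all, would give.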